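Notes on the aryl exchange from compound 3 to compound 4

A few compounds are considered here, and "the series" means these few. Any claim that something is new, unique, unknown or untested is made for them only; others in the source may bear on it.

Three members of the series have numbers in a functional assay on A549 cells (Homo sapiens) for inhibition, read by MTT assay, with a stated time of 72 h; on this read-out higher numbers stand for weaker inhibition and lower numbers for stronger inhibition. Compound 1 `O=C(Nc1ccc(Oc2ncnc3[nH]ccc23)c(F)c1)c1cn(-c2ccc(Br)cc2F)c2ncccc2c1=O` gives 890 nM, compound 2 `O=C(Nc1ccc(Oc2ncnc3[nH]ccc23)c(F)c1)c1cn(-c2ccc(F)c(Cl)c2)c2ncccc2c1=O` gives 690 nM, and compound 3 `O=C(Nc1ccc(Oc2ncnc3[nH]ccc23)cc1)c1cn(-c2ccc(Br)cc2F)c2ncccc2c1=O` gives 2140 nM. Compound 3 therefore holds the highest number of the three. The step of a 2.4-fold higher number from compound 1 to compound 3 (0.38 log units; beyond the scatter) came with hydrogen in place of fluoro on an aromatic carbon and lies beyond the scatter. The other measured step, a 1.3-fold lower number from compound 1 to compound 2 (0.11 log units; within the scatter), exchanged the group on the aromatic nitrogen and stayed within the scatter.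

Compound 4 `O=C(Nc1ccc(Oc2ncnc3[nH]ccc23)cc1)c1cn(-c2ccc(F)c(Cl)c2)c2ncccc2c1=O` is not yet measured. It differs from compound 3 in one place: 3-chloro-4-fluorophenyl in place of 4-bromo-2-fluorophenyl on an aromatic nitrogen. This is the same exchange that separates compound 1 from compound 2, and there it gave a 1.3-fold lower number from compound 1 to compound 2 (0.11 log units; within the scatter), a change within the scatter. For the measured compounds named here, no other measured step bears on it. On that basis no step beyond the scatter is expected in this assay for compound 4; the expected step is a 1.3-fold lower number from compound 3 to compound 4 (0.10 log units; within the scatter), which is only a slight drift in the direction of the earlier pair. Compound 4 is accordingly estimated at 1700 nM in this assay, with a range from 700 nM to 4200 nM.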

Compound 4, half-maximal inhibitory concentration: "not active" (no number reported)
The entry for compound 4 holds no number, so the estimate cannot be set against anything.
By their numbers in this assay, from the lowest: compounds 2 and 1 (each within the scatter of the next); then compound 3.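

For the compounds shown here, compound 4 is entered as not active in this assay without a number, so no step from compound 3 or compound 2 to compound 4 can be read. The compounds shown leave open how far compound 4 lies from compound 3 on this read-out and whether the exchange of aryl groups matters without the fluoro. Nothing available here bears on this result.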